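Neopentyl in Place of the Trifluoromethylbenzyl Arm

The source may report more compounds than this note shows. Statements on the series, on what has been measured and on what is new or still open speak of the compounds shown alone.

Compound 1 `Fc1ccc(C(SCCNC2CCN(Cc3ccc(C(F)(F)F)cc3)CC2)c2ccc(F)cc2)cc1` stands at the high end of the three numbers recorded in an assay on membranes from striatum (strain Sprague-Dawley) for displacement of a labelled ligand from sodium-dependent dopamine transporter (Rattus norvegicus), read by scintillation counting, with a stated time of 120 min (on this read-out lower numbers stand for stronger inhibition and higher numbers for weaker inhibition), where compound 1 gives 190 nM. Its nearest neighbour is compound 3 `O=C(c1cc2ccccc2o1)N1CCC(NCCSC(c2ccc(F)cc2)c2ccc(F)cc2)CC1`, which gives 115 nM in this assay, a gap described by a 1.7-fold lower number from compound 1 to compound 3 (0.22 log units; within the scatter). The furthest is compound 2 `O=C(c1ccccc1)N1CCC(NCCSC(c2ccc(F)cc2)c2ccc(F)cc2)CC1`, which gives 4.51 nM, a gap described by a 42-fold lower number from compound 1 to compound 2 (1.62 log units; beyond the scatter).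

Compound 4 `CC(C)(C)CN1CCC(NCCSC(c2ccc(F)cc2)c2ccc(F)cc2)CC1` departs from compound 1 at the group on the ring nitrogen: tert-butyl in place of 4-(trifluoromethyl)phenyl on a saturated chain carbon bound to an amine nitrogen in a ring. Both measured steps from compound 1 exchange the same 4-(trifluoromethyl)benzyl group, yet each brings in a carbonyl, which compound 4 lacks. One of them, a 42-fold lower number from compound 1 to compound 2 (1.62 log units; beyond the scatter), was large; the other, a 1.7-fold lower number from compound 1 to compound 3 (0.22 log units; within the scatter), stayed within the scatter. Among the measured compounds shown here, the neopentyl case has no close precedent among the three, so a modest step toward lower numbers, perhaps not beyond the scatter, is what is expected: a 1.7-fold lower number from compound 1 to compound 4 (0.24 log units; within the scatter). Compound 4 is therefore estimated at 110 nM, with a range from 25 nM to 500 nM.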

Compound 4, inhibition constant: 279 nM
For compound 4 the middle estimate is 2.5-fold (0.40 log units) below the measured one, and the stated range covers the measured number.
By their numbers in this assay, from the lowest: compound 2; then compounds 3, 1 and 4 (each within the scatter of the next, the first and the last beyond it).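

In this assay the exchange of the 4-(trifluoromethyl)benzyl arm for neopentyl gives a 1.5-fold higher number from compound 1 to compound 4 (0.17 log units; within the scatter) so this position tolerates the loss of the aromatic ring without a change that can be resolved. Set against the acylated arms, neopentyl gives a 2.4-fold higher number from compound 3 to compound 4 (0.38 log units; beyond the scatter) and a far larger a 62-fold higher number from compound 2 to compound 4 (1.79 log units; beyond the scatter) so the low number of compound 2 remains unique among these groups on the ring nitrogen, and the carbonyl of compound 3 shows that a carbonyl alone does not reproduce it. Nothing available here explains these differences.

Still open, as far as these compounds go, is whether the low number of compound 2 depends on the carbonyl, the phenyl or their combination. An unsubstituted benzyl or a pivaloyl group on the ring nitrogen would help separate these contributions.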